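Swapping the Sulfonamide for a Cyanocyclopropyl Group

The source may hold more compounds than are shown below. What is called first, only, known or untested is meant among the compounds shown, and "the series" means these compounds.

Of the compounds shown here, three sharing one core have been measured in an assay on Sf9 cells for inhibition of serine/threonine-protein kinase 4 (Homo sapiens), read by luminescence and ADP-Glo, with a stated time of 1 h, in the presence of a further agent that is not named here; on this read-out higher numbers stand for weaker inhibition and lower numbers for stronger inhibition. Compound 1 `CNS(=O)(=O)c1ccc(Nc2ncc3c(n2)N(C)C(c2ccccc2C)C(=O)N3C)cc1` gives 104 nM. Compound 2 `Cc1ccccc1C1C(=O)N(C)c2cnc(Nc3ccc(S(=O)(=O)N(C)C)cc3)nc2N1C` gives 219 nM, and compound 3 `Cc1ccccc1C1C(=O)N(C)c2cnc(Nc3ccc(S(=O)(=O)NC4CC4)cc3)nc2N1C` gives 53 nM. Compound 3 has the lowest number of the three, though the step of a 2.0-fold lower number from compound 1 to compound 3 (0.29 log units; within the scatter) lies within the scatter, while a 4.1-fold lower number from compound 2 to compound 3 (0.62 log units; beyond the scatter) is a modest step beyond it. The change a 2.1-fold higher number from compound 1 to compound 2 (0.32 log units; beyond the scatter) was also modest.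

The next compound, compound 4 `Cc1ccccc1C1C(=O)N(C)c2cnc(Nc3ccc(C4(C#N)CC4)cc3)nc2N1C`, keeps the core but carries a different group on the aromatic carbon: 1-cyanocyclopropyl in place of cyclopropylsulfamoyl on an aromatic carbon. Within the data shown here, none of the measured steps bears directly on this change, since each of them kept the sulfonyl group and varied only what sits on its nitrogen. Those steps were all modest in size. Among the measured compounds shown here, the entering group lacks the hydrogen-bond donor and one of the acceptors that the leaving group carried, and there is no close precedent among the measured compounds, so a moderate rise in the number with wide uncertainty is expected. Compound 4 is expected to give 160 nM, in a range from 40 nM to 650 nM. This corresponds to an estimated step of a 3.0-fold higher number from compound 3 to compound 4 (0.48 log units; beyond the scatter) in this assay.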

Compound 4, half-maximal inhibitory concentration: 256 nM
The estimate for compound 4 lay 1.6-fold (0.20 log units) below the measured number, and the stated range covers the measured number.
By their numbers in this assay, from the lowest: compounds 3 and 1 (each within the scatter of the next); then compounds 2 and 4 (each within the scatter of the next).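

Replacing the whole sulfonamide with 1-cyanocyclopropyl, rather than only varying what sits on its nitrogen, costs a modest amount against the cyclopropylsulfamoyl group in this assay: a 4.8-fold higher number from compound 3 to compound 4 (0.68 log units; beyond the scatter). Yet a group without sulfur can still stand on this aromatic carbon, since the change against dimethylsulfamoyl gives a 1.2-fold higher number from compound 2 to compound 4 (0.07 log units; within the scatter), while the change against methylsulfamoyl gives a modest 2.5-fold higher number from compound 1 to compound 4 (0.39 log units; beyond the scatter). Nothing available here explains these differences.

The compounds shown leave open whether the nitrile or the three-membered ring matters more for this result, a question that a plain cyclopropyl or a lone nitrile on the same aromatic carbon could help to separate. On these data alone, how a carboxylic acid or a simple amide would read at this position also remains open.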